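This account rests on a few compounds, and the source may have more. Where it says the series, first, only, none or still open, it means among the compounds named here.

Working notes. In a functional assay on NCI-H460 cells (Homo sapiens) for cytotoxicity, read by MTT assay, with a stated time of 72 h (a higher number here means a weaker inhibitor, a lower number a stronger inhibitor), compound 2 `CN(C)CCCNc1nc(-c2ccc(NC(=O)Nc3ccc(Cl)cc3)cc2)nc2c(Cl)c(Cl)sc12` gives 230 nM, the lowest of the three numbers in hand. Compound 1 `CN(C)CCCNc1nc(-c2ccc(NC(=O)Nc3ccc(F)cc3)cc2)nc2c(Cl)c(Cl)sc12` gives 650 nM in this assay, and the step of a 2.8-fold lower number from compound 1 to compound 2 (0.45 log units; beyond the scatter) is beyond the scatter. Compound 3 `Cc1ccc(NC(=O)Nc2ccc(-c3nc(NCCCN(C)C)c4sc(Cl)c(Cl)c4n3)cc2)cc1` gives 1110 nM in this assay, with the step of a 4.8-fold higher number from compound 2 to compound 3 (0.68 log units; beyond the scatter) also beyond the scatter, so compound 2 is the most potent of the measured set. Compound 4 `CN(C)CCNc1nc(-c2ccc(NC(=O)Nc3ccc(Cl)cc3)cc2)nc2c(Cl)c(Cl)sc12` differs from compound 2 only in the chain: dimethylamino in place of (dimethylamino)methyl on a saturated chain carbon, two bonds along the chain from a nitrogen on an aromatic ring. Among the compounds with values here, all measured steps, including a 1.7-fold higher number from compound 1 to compound 3 (0.23 log units; within the scatter), concern the aryl urea end, none the chain, so no step bears directly on this change. The expectation is therefore a step of a 1.3-fold higher number from compound 2 to compound 4 (0.12 log units; within the scatter) within the scatter in this assay. Compound 4 is estimated at 300 nM, range 100 nM to 900 nM.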

Compound 4, half-maximal inhibitory concentration: 300 nM
The estimate for compound 4 equals the measured number at the digits printed, within the range that was stated.
By their numbers in this assay, from the lowest: compounds 2 and 4 (each within the scatter of the next); then compounds 1 and 3 (each within the scatter of the next).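

In this assay, within the data shown here, the change from 3-(dimethylamino)propyl to 2-(dimethylamino)ethyl gives a 1.3-fold higher number from compound 2 to compound 4 (0.12 log units; within the scatter) and is the first measured step at the chain rather than the aryl urea end. With the chloro urea end held constant, this position accepts the change without a shift beyond the scatter, at least in this single pair. No evidence is available that explains this result.

Going by these compounds, whether the same holds with the fluoro or methyl urea ends of compound 1 and compound 3 remains open. Also open, on these data alone, is how a longer chain, or a diethylamino or morpholine group at the chain end, would read here.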